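The source may hold more compounds than are shown below. What is called first, only, known or untested is meant among the compounds shown, and "the series" means these compounds.

Three compounds with a shared core carry the same pentafluorophenylsulfonyl azetidine amide and differ in the two groups on the amide nitrogen. Compound 1 `CC(C)(C)c1ccc(CN(C(=O)[C@H]2CCN2S(=O)(=O)c2c(F)c(F)c(F)c(F)c2F)c2ccc(C(=O)NO)cc2F)cc1`, compound 2 `CNC(=O)c1ccc(N(Cc2ccc(C3CCCCC3)cn2)C(=O)[C@H]2CCN2S(=O)(=O)c2c(F)c(F)c(F)c(F)c2F)c(F)c1` and compound 3 `O=C([C@H]1CCN1S(=O)(=O)c1c(F)c(F)c(F)c(F)c1F)N(Cc1ccc(C2CCCCC2)cc1)c1ccc2c(=O)[nH]ncc2c1` were studied in a functional assay on MCF7 cells (Homo sapiens) for antiproliferative activity, with a stated time of 72 h; a higher number here means that more compound is needed for the effect, a lower number that less compound is needed. In this assay compound 3 gives 4500 nM. For compound 1 the entry in this assay reads "not determined" (no result reported), and for compound 2 it likewise reads "not determined" (no result reported), so compound 2 stands without a number.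

Compound 4 `O=C1NC(=O)c2cc(N(Cc3ccc(C4CCCCC4)cn3)C(=O)[C@H]3CCN3S(=O)(=O)c3c(F)c(F)c(F)c(F)c3F)ccc21` has not been measured. It differs from compound 2 in one place: a group of 11 heavy atoms (8 carbon, 1 nitrogen, 2 oxygen; one five-membered non-aromatic ring with 1 hetero atom, one six-membered aromatic ring of carbon only) in place of a group of 11 heavy atoms (8 carbon, 1 nitrogen, 1 oxygen, 1 fluorine; one six-membered aromatic ring of carbon only), on an amide-type nitrogen. The other group on that nitrogen, the cyclohexyl-bearing pyridine methyl arm, stays the same in both.

Compound 2 has no number in this assay. For the measured compounds named here, no step from compound 2 to compound 4 can be given a size or a direction. Going by the values given here, the only anchor is compound 3, which keeps the same sulfonyl azetidine and a similar cyclohexyl arm and gives 4500 nM in this assay. On that basis compound 4 is expected to land in the same region, around 4000 nM, with a plausible range from 1200 nM to 13000 nM, in this assay.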

Compound 4, half-maximal effective concentration: 7000 nM
For compound 4 the middle estimate is 1.8-fold (0.24 log units) below the measured one; low and high end bracket the measured number.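

In this assay, for the compounds shown here, compound 2 has no single number, so no step from it to compound 4 can be read. The compounds shown leave open whether replacing the 2-fluoro-4-(methylcarbamoyl)phenyl group on the amide-type nitrogen with the group of compound 4 changes the result at all, and in which direction. Nothing shown offers an explanation for the value of compound 4.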